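Compound 2 to compound 4: a thiazole replaces chloro

The compounds below may be only part of what the source reports. "The series", "measured", "known", "first", "only" and "open" are said of these compounds alone.

Measured in a toxicity assay on NIH3T3 cells (Mus musculus) for cytotoxicity, read by resazurin assay (on this read-out lower numbers stand for an effect already at smaller amounts and higher numbers for an effect only at larger amounts of compound), all three values being limits:
Compound 1 `Clc1ccc(NCc2cncn2Cc2ccc(-c3ccccc3)cc2)cc1-c1ccccc1`: > 1000 nM
Compound 2 `Nc1cc(-c2ccccc2)ccc1Cn1cncc1CNc1ccc(Cl)c(-c2ccccc2)c1`: > 1000 nM
Compound 3 `c1ccc(Cn2cncc2CNc2cccc(-c3ccncc3)c2)cc1`: > 1000 nM

Compound 2 stands at > 1000 nM, which is a limit and not a number. The other two compounds offer only limits as well. In compound 4 `Nc1cc(-c2ccccc2)ccc1Cn1cncc1CNc1ccc(-c2cncs2)c(-c2ccccc2)c1`, 1,3-thiazol-5-yl takes the place of chloro on an aromatic carbon (1,3-thiazol-5-yl in place of chloro on an aromatic carbon). Among the compounds with values here, the one measured step that bears on this is a step that the two limits leave unreadable from compound 1 to compound 2, and it gives no size to work from. Compound 2 shares (the limit of > 1000 nM in this assay, at which 3 of the 3 values shown sit), so no step beyond the scatter is expected in this assay, in either direction. The estimated change is a step that the limit leaves unreadable from compound 2 to compound 4. For compound 4 the expected value is 2000 nM, with an estimated range from 500 nM to 10000 nM.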

Compound 4, half-maximal effective concentration: > 1000 nM
Compound 4 ended at the assay's limit (the forecaster's own chance of this, stated with the estimate: 80%); the middle value lies beyond the limit too.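

Within the data shown here, compound 2 and compound 4 both end at a limit in this assay, and no step between them can be read. The compounds shown leave open whether 1,3-thiazol-5-yl in place of chloro changes the cytotoxicity at all.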